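Trifluoromethoxy added to the sulfonyl ring of compound 2

The source may report more compounds than this note shows. Statements on the series, on what has been measured and on what is new or still open speak of the compounds shown alone.

Compound 2 `O=S(=O)(Nc1cccc(CO)c1)c1ccc(-c2ccc(F)cc2)cc1` gives 3500 nM in a functional assay on J774 cells (Mus musculus) for cytotoxicity, read by resazurin assay, with a stated time of 72 h (on this read-out lower numbers stand for stronger inhibition and higher numbers for weaker inhibition), the highest number among the three measured compounds. Compound 1 `O=S(=O)(Nc1cccc(CO)c1)c1ccc(-c2ccc3cc[nH]c3c2)cc1` gives 2500 nM in this assay, and compound 3 `O=S(=O)(Nc1cccc(CO)c1)c1ccc(-c2ccc(Cl)cc2F)cc1` gives 700 nM. The steps measured so far all concern the group at the far end of the shared core: a 1.4-fold higher number from compound 1 to compound 2 (0.15 log units; within the scatter), a 3.6-fold lower number from compound 1 to compound 3 (0.55 log units; beyond the scatter) and a 5.0-fold lower number from compound 2 to compound 3 (0.70 log units; beyond the scatter). Compound 4 `O=S(=O)(Nc1cccc(CO)c1)c1ccc(-c2ccc(F)cc2)cc1OC(F)(F)F` differs from compound 2 by trifluoromethoxy in place of hydrogen on an aromatic carbon. Within the data shown here, none of the measured steps touches that ring, so no measured pair bears directly on this change, and nothing in the three numbers points to a shift in either direction. On that basis compound 4 is expected to give about 3000 nM in this assay, with a range from 1000 nM to 9000 nM. The estimate means a step of a 1.2-fold lower number from compound 2 to compound 4 (0.07 log units; within the scatter) that is expected to stay within the scatter.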

Compound 4, half-maximal inhibitory concentration: 1000 nM
Beside the measured number, compound 4's estimate is 3.0-fold (0.48 log units) above it; the measured number falls inside the stated range.
By their numbers in this assay, from the lowest: compounds 3 and 4 (each within the scatter of the next); then compounds 1 and 2 (each within the scatter of the next).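

In this assay the change gives a 3.5-fold lower number from compound 2 to compound 4 (0.54 log units; beyond the scatter), so trifluoromethoxy in place of hydrogen, ortho to a large group and meta to a 4-fluorophenyl group, moves the number beyond the scatter towards stronger inhibition. Among these compounds, the earlier steps all changed the group at the far end of the shared core, so this is the first sign that a change at another place on that core also counts. Nothing shown here accounts for the size or direction of this step.

Going by these compounds, whether a methoxy group, a chlorine atom or an amine on the same carbon would act as trifluoromethoxy does remains open. So does whether the step would carry over to compounds with the 4-chloro-2-fluorophenyl group of compound 3 or the 1H-indol-6-yl group of compound 1.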